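A few compounds are considered here, and "the series" means these few. Any claim that something is new, unique, unknown or untested is made for them only; others in the source may bear on it.

Compound 1 `CC(=O)c1c(N2CCCCC2)[nH]c2c(F)cc(F)cc2c1=O`: > 25000 nM
Compound 2 `CC(=O)c1c(NCc2ccc(F)cc2)[nH]c2c(F)cc(F)cc2c1=O`: > 25000 nM

In an ADME assay on Vero cells (Chlorocebus sabaeus) for cytotoxicity (on this read-out higher numbers stand for lower toxicity in this test and lower numbers for higher toxicity in this test), compound 2 gives > 25000 nM, which is a limit and not a number. Compound 1 gives > 25000 nM, also a limit. Compound 2 therefore stands at the limit of > 25000 nM in this assay, at which 2 of the 2 values shown sit.

Compound 3 `CC(=O)c1c(Nc2ccc(Br)cc2)[nH]c2c(F)cc(F)cc2c1=O` carries 4-bromophenyl in place of 4-fluorobenzyl on a nitrogen on an aromatic ring.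

Within the data shown here, no measured step is available. In this assay a change no larger than the usual scatter is expected, and this expectation rests on the limit of compound 2, > 25000 nM. The expected change is an at least 1.2-fold lower number from compound 2 to compound 3 (0.09 log units; that floor lies within the scatter). For compound 3 the estimated value is 20000 nM, with an expected range of 7000 nM to 25000 nM.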

Compound 3, half-maximal cytotoxic concentration: > 25000 nM
Compound 3 was reported as a limit (the forecaster's own chance of this, stated with the estimate: 60%); middle value at least 1.2-fold (0.09 log units) from the limit.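

In this assay compound 3 gives > 25000 nM, a limit and not a number; compound 1 and compound 2 also stand at limits, so the steps from either to compound 3 cannot be read. The compounds shown leave open whether piperidin-1-yl, 4-fluorobenzyl or 4-bromophenyl on the shared core makes any difference in this assay.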